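The source may report more compounds than this note shows. Statements on the series, on what has been measured and on what is new or still open speak of the compounds shown alone.

Among the measured compounds shown here, in a functional assay on KB cells (Homo sapiens) for antiproliferative activity, read by sulforhodamine B assay, with a stated time of 3 days (a lower number here means that less compound is needed, a higher number that more compound is needed for the effect), compound 2 (`CCC1=C(O)c2c(oc(-c3ccc(C)c(F)c3)cc2=O)C(CC)(CC)C1=O`) gives 28.1 uM, the only actual number so far. In this assay, compound 1 (`CCOc1ccc(-c2cc(=O)c3c(o2)C(CC)(CC)C(=O)C(CC)=C3O)cc1`) gives only a limit, > 52.4 uM. Compound 3 (`CCC1=C(O)c2c(oc(-c3cc(C)c(O)c(C)c3)cc2=O)C(CC)(CC)C1=O`) differs from compound 2 by 4-hydroxy-3,5-dimethylphenyl in place of 3-fluoro-4-methylphenyl on an aromatic carbon. For the measured compounds named here, the one measured step bearing on this aromatic position is an at least 1.8-fold lower number from compound 1 to compound 2 (0.27 log units; that floor lies within the scatter). It therefore gives no firm direction, and no change beyond the scatter is expected in this assay. The expected step is a 1.3-fold lower number from compound 2 to compound 3 (0.11 log units; within the scatter). For compound 3 the estimated value is 22 uM, with an expected range of 8 uM to 55 uM.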

Compound 3, concentration for half-maximal effect: 18.3 uM
Compound 3: the middle estimate sits 1.2-fold (0.08 log units) above what was measured; low and high end bracket the measured number.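

In this assay, putting 4-hydroxy-3,5-dimethylphenyl in place of 3-fluoro-4-methylphenyl gives a 1.5-fold lower number from compound 2 to compound 3 (0.19 log units; within the scatter) and so does not separate these two groups at this aromatic carbon. Among the compounds shown here, replacing 4-ethoxyphenyl with 4-hydroxy-3,5-dimethylphenyl gives the first step here to clear the scatter, with an at least 2.8-fold lower number from compound 1 to compound 3 (0.45 log units; beyond the scatter) as its floor. Compound 1 enters that step only as a limit, so its full size cannot be read: the limit of > 52.4 uM in this assay, at which 1 of the 3 values shown sits.

On these data alone, whether an amine or a carboxylic acid on this phenyl ring would move the number remains open.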